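Swapping a Phenyl for a Hydroxymethyl on the Side Chain

A few compounds are considered here, and "the series" means these few. Any claim that something is new, unique, unknown or untested is made for them only; others in the source may bear on it.

Compound 2 `O=C1NS(=O)(=O)N(COCc2ccccc2)c2ccccc21` carries a benzyl group on the chain attached to the core. In a functional assay on HEL cells (Homo sapiens) for cytotoxicity (on this read-out lower numbers stand for higher toxicity in this test and higher numbers for lower toxicity in this test), compound 2 reaches only a limit of the assay, > 50 ug/mL. Its neighbour, compound 1 `CCCOCN1c2ccccc2C(=O)NS1(=O)=O`, also stops at a limit in this assay, > 50 ug/mL. Among the compounds with values here, the single measured step, a step that the two limits leave unreadable from compound 1 to compound 2, cannot be sized, since both of its ends are limits. Both values sit at the limit of > 50 ug/mL in this assay, at which 2 of the 2 values shown sit.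

Compound 3 `O=C1NS(=O)(=O)N(COCCO)c2ccccc21` differs from compound 2 by hydroxymethyl in place of phenyl on a saturated chain carbon bound to an oxygen on a saturated carbon. No readable measured step bears on this change, so the expectation rests on the two limits alone. For compound 3 a step of a number no higher from compound 2 to compound 3 (the limit leaves the size open) is expected in this assay, meaning no change that the test can register. Compound 3 is therefore estimated at 50 ug/mL, with a range from 25 ug/mL to 100 ug/mL.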

Compound 3, minimum cytotoxic concentration: > 50 ug/mL
Compound 3: no number, only a limit; the forecaster's own chance of this, stated with the estimate: 85%; the middle value lies on the limit itself.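

In this assay, within the data shown here, compound 3 stops at a limit, > 50 ug/mL, so no step to it from compound 1 or compound 2 can be read. The compounds shown leave open whether changing the side chain on the shared core alters this read-out at all: the limit of > 50 ug/mL in this assay, at which 3 of the 3 values shown sit.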